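The source may report more compounds than this note shows. Statements on the series, on what has been measured and on what is new or still open speak of the compounds shown alone.

The measured compounds are:
compound 1, `C=C(Br)C(=O)Nc1cccc(-c2cn3nc(Cc4ccc(OC)cc4)sc3n2)c1`, giving 850 nM in a functional assay on FM3A cells (Mus musculus) for inhibition, read by cell counting, with a stated time of 2 days; on this read-out lower numbers stand for stronger inhibition and higher numbers for weaker inhibition;
compound 2, `C=C(Br)C(=O)Nc1cccc(-c2cn3nc(-c4cccs4)sc3n2)c1`, giving 370 nM;
compound 3, `C=C(Br)C(=O)Nc1cccc(-c2cn3nc(-c4ccc(F)cc4)sc3n2)c1`, giving 610 nM.

Compound 3 stands second highest of the three numbers in this assay. Its nearest neighbour is compound 1, with the step of a 1.4-fold lower number from compound 1 to compound 3 (0.14 log units; within the scatter), and its furthest is compound 2, with the step of a 1.6-fold higher number from compound 2 to compound 3 (0.22 log units; within the scatter); both of these lie within the scatter, so compound 3 cannot be ordered against either of them. Among the measured compounds shown here, the only step beyond the scatter among the measured compounds is a 2.3-fold lower number from compound 1 to compound 2 (0.36 log units; beyond the scatter).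

Compound 4, `C=C(Br)C(=O)Nc1cccc(-c2cn3nc(-c4cccc(OC)c4)sc3n2)c1`, differs from compound 3 in one place: 3-methoxyphenyl in place of 4-fluorophenyl on an aromatic carbon. For the measured compounds named here, no measured step exchanges one substituted phenyl for another at this position, so the bearing of the earlier steps is indirect. The step of a 1.4-fold lower number from compound 1 to compound 3 (0.14 log units; within the scatter) shows that a larger exchange at the same carbon moved the number only within the scatter, and a 1.6-fold higher number from compound 2 to compound 3 (0.22 log units; within the scatter) did likewise. On that basis the expected step of a 1.0-fold lower number from compound 3 to compound 4 (0.01 log units; within the scatter) is small and of no clear direction. Compound 4 is therefore estimated at 600 nM in this assay, with a range from 250 nM to 1500 nM.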

Compound 4, half-maximal inhibitory concentration: 500 nM
Estimate against measurement, compound 4: 1.2-fold (0.08 log units) above; the measured number falls inside the stated range.
By their numbers in this assay, from the lowest: compounds 2, 4, 3 and 1 (each within the scatter of the next, the first and the last beyond it).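

Among the compounds shown here, this is the first exchange of one substituted phenyl for another on this carbon, next to the ring nitrogen and the ring sulfur, and in this assay it gives a step within the scatter (a 1.2-fold lower number from compound 3 to compound 4 (0.09 log units; within the scatter)), even though 3-methoxyphenyl brings an oxygen and a hydrogen-bond acceptor that 4-fluorophenyl lacks. Compound 4 cannot be ordered against either of the two compounds that are separated beyond the scatter, as it lies within the scatter of both (a 1.4-fold higher number from compound 2 to compound 4 (0.13 log units; within the scatter); a 1.7-fold lower number from compound 1 to compound 4 (0.23 log units; within the scatter)). For the compounds shown here, with the thiophen-2-yl and 4-methoxybenzyl compounds still the only pair set apart, the new phenyl adds no further separation among the groups at this carbon.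

Nothing available here explains why these numbers lie as they do. Also open, from the compounds shown here alone, is whether a group without an aromatic ring on this carbon, such as an amine, a carboxylic acid or a butyl chain, would stay within this span, and whether 4-methoxyphenyl or 3-fluorophenyl would read like the two phenyl groups seen so far.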